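The compounds below may be only part of what the source reports. "The series", "measured", "known", "first", "only" and "open" are said of these compounds alone.

Measured so far in an ADME assay on cells (Hepatocyte, Rattus norvegicus, strain Wistar) for pharmacokinetics, read by LC-MS, with a stated time of 90 min, tested at 1 uM; a higher number here means faster removal of the compound, a lower number slower removal:
- compound 1 `COc1cc(C(=O)N2CC[C@@H](O)C(C)(C)C2)cc2nc(NCc3cccc(Cl)c3)oc12` gives 51.7 mL/min/kg
- compound 2 `COc1cc(C(=O)N2CC[C@@H](O)[C@H](C)C2)cc2nc(NCc3cccc(Cl)c3)oc12` gives 38.3 mL/min/kg
- compound 3 `COc1cc(C(=O)N2CC[C@H](O)[C@@H](C)C2)cc2nc(NCc3cccc(Cl)c3)oc12` gives 36.7 mL/min/kg

Compound 3 stands level with compound 2, with a 1.0-fold lower number from compound 2 to compound 3 (0.02 log units; within the scatter). It also lies within the scatter of compound 1, with a 1.4-fold lower number from compound 1 to compound 3 (0.15 log units; within the scatter).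

Compound 4 `COc1cc(C(=O)N2CC(C)C(O)CC2CCO)cc2nc(NCc3cccc(Cl)c3)oc12` follows from compound 3 through this change: 4-hydroxy-2-(2-hydroxyethyl)-5-methylpiperidin-1-yl in place of 4-hydroxy-3-methylpiperidin-1-yl on a carbonyl carbon.

The nearest measured changes at this carbonyl carbon are a 1.3-fold lower number from compound 1 to compound 2 (0.13 log units; within the scatter) and a 1.4-fold lower number from compound 1 to compound 3 (0.15 log units; within the scatter). Going by the values given here, both stay within the scatter, and no measured compound carries the 2-hydroxyethyl group. Expected in this assay is therefore no shift beyond the scatter, with a 1.2-fold lower number from compound 3 to compound 4 (0.09 log units; within the scatter) as the estimated step.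

For compound 4 the estimated clearance is 30 mL/min/kg, with an expected range from 15 mL/min/kg to 55 mL/min/kg.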

Compound 4, clearance: 4.5 mL/min/kg
Compound 4: middle estimate off by 6.7-fold (0.82 log units), on the high side; measured number below the stated range.
By their numbers in this assay, from the lowest: compound 4; then compounds 3, 2 and 1 (each within the scatter of the next).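

Going by these compounds alone, the change to 4-hydroxy-2-(2-hydroxyethyl)-5-methylpiperidin-1-yl on the carbonyl carbon gives the first steps beyond the scatter at this place, with an 8.2-fold lower number from compound 3 to compound 4 (0.91 log units; beyond the scatter), an 8.5-fold lower number from compound 2 to compound 4 (0.93 log units; beyond the scatter) and an 11-fold lower number from compound 1 to compound 4 (1.06 log units; beyond the scatter) all pointing the same way. The earlier changes here, in methyl count and in configuration, all stayed within the scatter, so clearance at this place is not insensitive to substitution.

As far as these compounds go, whether a hydroxymethyl group, a 2-aminoethyl chain or a carboxylic acid in place of the 2-hydroxyethyl group would give a step of this size stays open, as does the role of configuration in compound 4, which has no defined stereocentres. Nothing shown here accounts for the lower number.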